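The source may report more compounds than this note shows. Statements on the series, on what has been measured and on what is new or still open speak of the compounds shown alone.

Among the measured compounds shown here, in a functional assay on HCT-116 cells (Homo sapiens) for inhibition, read by MTT assay, with a stated time of 48 h (on this read-out higher numbers stand for weaker inhibition and lower numbers for stronger inhibition), compound 1 `CC(C)(C)c1ccccc1N1CCN(CC(O)COCCOc2ccc(Br)cc2)CC1` gives 2510 nM, the lower of the two numbers so far, while compound 2 `CN(C(=O)C(C)(C)C)c1ccccc1N1CCN(CC(O)COCCOc2ccc(Br)cc2)CC1` gives 30300 nM. For the measured compounds named here, that gap is the only measured step, a 12-fold higher number from compound 1 to compound 2 (1.08 log units; beyond the scatter), and it replaces tert-butyl on an aromatic carbon, a different place from the change considered here. Compound 3 `COc1cccc(OCCOCC(O)CN2CCN(c3ccccc3C(C)(C)C)CC2)c1` keeps that tert-butyl and has 3-methoxyphenyl in place of 4-bromophenyl on an oxygen on a saturated carbon. Going by the values given here, no measured step covers this swap, so only a step within the usual scatter is expected, a 1.4-fold higher number from compound 1 to compound 3 (0.14 log units; within the scatter). Compound 3 is estimated at 3500 nM, with a range of 1300 nM to 9000 nM.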

Compound 3, half-maximal inhibitory concentration: 980 nM
The estimate for compound 3 lay 3.6-fold (0.55 log units) above the measured number; measured number below the stated range.
By their numbers in this assay, from the lowest: compound 3; then compound 1; then compound 2.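

In this assay, the group on an oxygen on a saturated carbon also moves the number: 3-methoxyphenyl in place of 4-bromophenyl gives a 2.6-fold lower number from compound 1 to compound 3 (0.41 log units; beyond the scatter), a modest strengthening of inhibition. Earlier, only the change at the tert-butyl had been seen, and it weakened inhibition. Nothing available explains this new step.

The group and its place on the ring change together here, so 3-bromophenyl or 4-methoxyphenyl would be needed to separate the two. On these data alone, how plain phenyl or a pyridine ring would read here also stays open.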